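Ring size at the amine carried by the shared core

The compounds below may be only part of what the source reports. "The series", "measured", "known", "first", "only" and "open" are said of these compounds alone.

Measured so far in a functional assay on CHO-K1 cells for antagonist activity at transient receptor potential cation channel subfamily V member 1 (Homo sapiens), read by FLIPR; a lower number here means a stronger inhibitor, a higher number a weaker inhibitor:
- compound 1, `CC(C(=O)NCc1ccc(C(F)(F)F)nc1NC1CCCCC1)c1ccc(NS(C)(=O)=O)c(F)c1`: 20.4 nM
- compound 2, `Cc1ccc(Nc2nc(C(F)(F)F)ccc2CNC(=O)C(C)c2ccc(NS(C)(=O)=O)c(F)c2)cc1C`: 39.3 nM
- compound 3, `CC(C(=O)NCc1ccc(C(F)(F)F)nc1N1CCC(C)(C)CC1)c1ccc(NS(C)(=O)=O)c(F)c1`: 0.3 nM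

Compound 3 gives the lowest number of the three; compound 1 is nearest to it, a 68-fold lower number from compound 1 to compound 3 (1.83 log units; beyond the scatter), and compound 2 furthest, a 130-fold lower number from compound 2 to compound 3 (2.12 log units; beyond the scatter). Between compound 1 and compound 2 the step is a 1.9-fold higher number from compound 1 to compound 2 (0.28 log units; within the scatter).

Compound 4, `CC(C(=O)NCc1ccc(C(F)(F)F)nc1N1CCCCCC1)c1ccc(NS(C)(=O)=O)c(F)c1`, is not yet measured. Its change: azepan-1-yl in place of 4,4-dimethylpiperidin-1-yl on an aromatic carbon

Among the compounds with values here, the steps that bear on it are those into compound 3, both large, and both replace a substituent bearing a hydrogen-bond donor with a ring that keeps none; compound 4 keeps that ring type and changes only its size, losing the 4,4-dimethyl branches. A modest rise is therefore expected, a 6.7-fold higher number from compound 3 to compound 4 (0.82 log units; beyond the scatter), in this assay. Compound 4 is estimated at 2 nM, range 0.4 nM to 10 nM.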

Compound 4, inhibition constant: 0.8 nM
Compound 4: middle estimate off by 2.5-fold (0.40 log units), on the high side; low and high end bracket the measured number.
By their numbers in this assay, from the lowest: compound 3; then compound 4; then compounds 1 and 2 (each within the scatter of the next).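

In this assay, the azepan-1-yl ring keeps most of the gain over the amino-linked groups, with a 26-fold lower number from compound 1 to compound 4 (1.41 log units; beyond the scatter) and a 49-fold lower number from compound 2 to compound 4 (1.69 log units; beyond the scatter), both large, against a modest 2.7-fold higher number from compound 3 to compound 4 (0.43 log units; beyond the scatter). The large gain at this position therefore does not require the 4,4-dimethyl branches or a six-membered ring, although exchanging that ring still costs a step beyond the scatter. No measurement here gives a cause for these steps.

Ring size and branching change together between compound 3 and compound 4, so their separate contributions remain open. Also open, going by these compounds, is how unsubstituted piperidin-1-yl, pyrrolidin-1-yl or morpholin-4-yl would compare at this position.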